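This account rests on a few compounds, and the source may have more. Where it says the series, first, only, none or still open, it means among the compounds named here.

Compound 2, with the structure `CCC/C=C/C(=O)Nc1cc2c(N3CCCc4ccccc43)ncnc2cc1O[C@@H]1CCOC1`, is the weaker of the two measured compounds: in a functional assay on MCF7 cells (Homo sapiens) for antiproliferative activity, read by MTT assay, with a stated time of 72 h (on this read-out higher numbers stand for weaker inhibition and lower numbers for stronger inhibition), compound 2 gives 4230 nM, whereas compound 1, with the structure `CCC/C=C/C(=O)Nc1cc2c(N3CCCc4ccccc43)ncnc2cc1OC`, gives 1210 nM. For the measured compounds named here, the only measured step, a 3.5-fold higher number from compound 1 to compound 2 (0.54 log units; beyond the scatter), concerns a change on an oxygen on an aromatic ring and says nothing about the chain that carries the double bond.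

Compound 3, with the structure `O=C(/C=C/CN1CCCCC1)Nc1cc2c(N3CCCc4ccccc43)ncnc2cc1O[C@@H]1CCOC1`, differs from compound 2 only at that chain: piperidin-1-yl in place of ethyl on a saturated chain carbon bound to a double-bonded chain carbon. No measured pair in this set changes this part of the molecule, so the direction and size of the step from compound 2 to compound 3 cannot be read from the numbers shown. With that uncertainty, the number for compound 3 in this assay is expected to lie near that of compound 2 or somewhat lower; the step of a 1.7-fold lower number from compound 2 to compound 3 (0.23 log units; within the scatter) is an estimate only. Compound 3 is therefore estimated at 2500 nM, within a range from 800 nM to 8000 nM.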

Compound 3, half-maximal inhibitory concentration: 4450 nM
Beside the measured number, compound 3's estimate is 1.8-fold (0.25 log units) below it, and the stated range covers the measured number.
By their numbers in this assay, from the lowest: compound 1; then compounds 2 and 3 (each within the scatter of the next).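

For the compounds shown here, this is the first measured change at the far end of the chain, on a saturated chain carbon bound to a double-bonded chain carbon, and in this assay it makes no readable difference, with a 1.1-fold higher number from compound 2 to compound 3 (0.02 log units; within the scatter). Ethyl gives way to piperidin-1-yl, which brings in a six-membered non-aromatic ring holding a nitrogen, yet compound 2 and compound 3 cannot be told apart on this read-out, so in this pair the position takes the bigger group without a measurable penalty. No measurement available here offers an explanation for this result.

Going by these compounds, whether the same swap would read alike with the methyl of compound 1 on the oxygen remains open. So does the outcome at this chain carbon for other groups, such as a dimethylamino group, a morpholine ring or a carboxylic acid.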